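Swapping methyl for isopropyl on a ring nitrogen

This account rests on a few compounds, and the source may have more. Where it says the series, first, only, none or still open, it means among the compounds named here.

- Compound 1 `CCOc1ccc(-c2cc3c(cn2)[nH]c(=O)n3-c2cc(OC)c(OC)c(OC)c2)cc1F`: 2540 nM
- Compound 2 `COc1ccc(-c2cc3c(cn2)ncn3-c2cc(OC)c(OC)c(OC)c2)cc1O`: 360 nM
- Compound 3 `COc1ccc(-c2cc3c(cn2)n(C)c(=O)n3-c2cc(OC)c(OC)c(OC)c2)cc1O`: 3520 nM

All three values come from a functional assay on A549 cells (Homo sapiens) for antiproliferative activity, read by MTT assay, with a stated time of 48 h; a lower number here means a stronger inhibitor, a higher number a weaker inhibitor. Compound 3, at 3520 nM, lies within the usual scatter of compound 1, at 2540 nM. The gap from compound 3 to compound 2, at 360 nM, lies beyond the scatter, and compound 2 is the stronger inhibitor of that pair.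

The next compound, compound 4 `COc1ccc(-c2cc3c(cn2)n(C(C)C)c(=O)n3-c2cc(OC)c(OC)c(OC)c2)cc1O`, keeps everything in compound 3 except one group: isopropyl in place of methyl on an aromatic nitrogen. For the measured compounds named here, no two measured compounds differ in only one place, so the data show no direct precedent for this change. The nearest hint is weak. That nitrogen carries a hydrogen in compound 1, at 2540 nM, and a methyl in compound 3, at 3520 nM, and these values sit within the scatter, although the two compounds also differ elsewhere.

In this assay, a small move toward a weaker inhibitor is expected, probably no larger than the scatter. The estimated change is a 1.3-fold higher number from compound 3 to compound 4 (0.11 log units; within the scatter). For compound 4 the expected value is 4500 nM, with an estimated range from 1800 nM to 12000 nM.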

Compound 4, half-maximal inhibitory concentration: 7210 nM
Compound 4: the middle estimate sits 1.6-fold (0.20 log units) below what was measured; low and high end bracket the measured number.
By their numbers in this assay, from the lowest: compound 2; then compounds 1 and 3 (each within the scatter of the next); then compound 4.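

For the compounds shown here, this is the first direct reading of a single change at this ring nitrogen. Within this assay the swap of methyl for isopropyl gives a 2.0-fold higher number from compound 3 to compound 4 (0.31 log units; beyond the scatter) with nothing else altered in the structure, so this modest move toward a weaker inhibitor belongs to this one position. The earlier hint from compound 1 could not establish this. That compound also differs elsewhere. The compounds shown give the direction and size of this step, but no measurement here explains it.

A single step between two groups cannot establish a trend with size, so an ethyl group, a longer chain or a cyclopropyl ring on this nitrogen could fall anywhere relative to methyl and isopropyl. Also open, on these data alone, is how the rest of compound 3 would read with the amide hydrogen in place of methyl, a comparison that would turn the loose hint from compound 1 into a direct step.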